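Pyridin-3-yl to 3,4-Difluorophenyl: What to Expect

The compounds below may be only part of what the source reports. "The series", "measured", "known", "first", "only" and "open" are said of these compounds alone.

Of the compounds shown here, two built on a shared core have been measured so far. Compound 1 `COC(=O)Nc1cc(NC(=O)c2cccs2)cc(C(F)(F)F)c1` in an assay on HEK293-TREx cells for antagonist activity at transient receptor potential cation channel subfamily A member 1 (Homo sapiens), read by calcium flux (a higher number here means a weaker inhibitor, a lower number a stronger inhibitor), gives 2300 nM. Compound 2 `CCCNc1cc(NC(=O)c2cccnc2)cc(C(F)(F)F)c1` in this assay gives 940 nM, the lower of the two numbers; its gap to compound 1 lies beyond the usual scatter, so compound 2 is the stronger inhibitor of the pair. Compound 3 `CCCNc1cc(NC(=O)c2ccc(F)c(F)c2)cc(C(F)(F)F)c1` has not yet been measured. It differs from compound 2 in a single place: 3,4-difluorophenyl in place of pyridin-3-yl on a carbonyl carbon. Within the data shown here, no measured pair in this small set shows what such a swap does, so nothing here tells in which direction the number will move. With the amide kept and only the ring on its carbonyl carbon exchanged, the change is expected to be modest, a step that may not reach beyond the scatter, with a slight gain taken as the best guess. Compound 3 is expected to give 600 nM in this assay, within a range from 200 nM to 2000 nM. That estimate amounts to an expected step of a 1.6-fold lower number from compound 2 to compound 3 (0.19 log units; within the scatter).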

Compound 3, half-maximal inhibitory concentration: 1200 nM
Beside the measured number, compound 3's estimate is 2.0-fold (0.30 log units) below it; low and high end bracket the measured number.
By their numbers in this assay, from the lowest: compounds 2, 3 and 1 (each within the scatter of the next, the first and the last beyond it).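

In this assay, exchanging pyridin-3-yl for 3,4-difluorophenyl on the carbonyl carbon gives a 1.3-fold higher number from compound 2 to compound 3 (0.11 log units; within the scatter), so this pair cannot be told apart by this measurement. The group on this carbon goes from a ring with 1 hetero atom and 1 hydrogen-bond acceptor to a carbon-only ring with 0 hydrogen-bond acceptors, and from 6 heavy atoms to 8, yet the step stays within the scatter, so in this pair the ring nitrogen of pyridin-3-yl is not needed to keep the number in the same range. No other data are available to explain why the two compounds read so alike.

From the compounds shown here alone, both rings here are flat, six-membered and aromatic, so it remains open whether the position would tolerate something quite different, such as a saturated piperidine ring or a phenyl ring carrying a carboxylic acid. Two fluorines arrive together in compound 3, and a plain phenyl or a single-fluorine 4-fluorophenyl group would be needed to show whether either fluorine matters on its own.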